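The compounds below may be only part of what the source reports. "The series", "measured", "known", "first", "only" and "open" are said of these compounds alone.

Compound 1 `O=C(/C(=C\c1c(O)cc(O)cc1O)S(=O)(=O)c1ccccc1Br)c1ccc(Br)cc1` was run in a functional assay on DU-145 cells (Homo sapiens) for inhibition, read by trypan blue exclusion, with a stated time of 96 h (on this read-out higher numbers stand for weaker inhibition of growth and lower numbers for stronger inhibition of growth), where compound 1 gives 50000 nM. Compound 2 `O=C(/C(=C\c1ccc(O)cc1O)S(=O)(=O)c1ccccc1Br)c1ccc(Br)cc1` shares the core of compound 1 and differs from it in one place: hydrogen in place of hydroxy on an aromatic carbon. In this assay compound 2 reaches only a limit of the measurement, > 100000 nM. The change is recorded as an at least 2.0-fold higher number from compound 1 to compound 2 (0.30 log units; that floor lies within the scatter), so removing this hydroxy group did not make growth inhibition stronger, though the step as such is no larger than repeated measurements can separate.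

Compound 3 `O=C(/C(=C\c1c(O)cc(O)cc1O)Sc1ccccc1Br)c1ccc(Cl)cc1` has a core that differs from the core of compound 1 in more than one place; the difference between the two cores is not broken down here. In this assay compound 3 gives only a limit, > 100000 nM. Compound 4 `O=C(/C(=C\c1ccc(O)cc1O)Sc1ccccc1Br)c1ccc(Cl)cc1` has not yet been measured; it stands to compound 3 as compound 2 stands to compound 1, with the same change in the same surroundings: hydrogen in place of hydroxy on an aromatic carbon.

Compound 4 is expected to sit at or beyond the limit as well, because the limit of > 100000 nM in this assay, at which 2 of the 3 values shown sit, and because the earlier step of an at least 2.0-fold higher number from compound 1 to compound 2 (0.30 log units; that floor lies within the scatter) did not pull the number down. The step from compound 3 is therefore estimated as a step that the limit leaves unreadable from compound 3 to compound 4. For compound 4 the expected value is 200000 nM, estimated to lie between 100000 nM and 1000000 nM.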

Compound 4, concentration for 50% growth inhibition: 50000 nM
Compound 4: middle estimate off by 4.0-fold (0.60 log units), on the high side, and the stated range ends above it.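

In this assay, replacing one hydroxy with hydrogen, which turns 2,4,6-trihydroxyphenyl into 2,4-dihydroxyphenyl, gives an at least 2.0-fold lower number from compound 3 to compound 4 (0.30 log units; that floor lies within the scatter), so on this core the number goes down, whereas it went up on the core of compound 1. The change therefore does not carry over from one core to the other with the same direction of effect, and the two steps differ by more than measurement scatter can account for: the same change on two cores in this assay, an at least 2.0-fold higher number (0.30 log units; that floor lies within the scatter) from compound 1 to compound 2 and an at least 2.0-fold lower number (0.30 log units; that floor lies within the scatter) from compound 3 to compound 4, at least 4.0-fold (0.60 log units) apart, beyond the scatter of two such steps What this does not show is the true size of either step or which difference between the two cores reverses the direction, as compound 2 and compound 3 each stand at a limit of the assay and not at a number: the limit of > 100000 nM in this assay, at which 2 of the 4 values shown sit.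

The compounds shown leave open whether the outcome depends on the sulfonyl link of compound 1 or on its bromo group, as the cores differ in both and a pair differing in only one of these features would be needed to separate them. They also leave open what a methoxy group or an amine in place of the same hydroxy would give in this assay.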